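A few compounds are considered here, and "the series" means these few. Any claim that something is new, unique, unknown or untested is made for them only; others in the source may bear on it.

Values in a functional assay on HeLa cells (Homo sapiens) for inhibition, with a stated time of 48 h, tested at 50 uM (a lower number here means less inhibition of growth, a higher number more inhibition of growth at the concentration tested), as measured so far:
- compound 1 `C=C[C@@](C)(/C=C/c1ccc(OC(=O)CCCCCCC)cc1)CCC=C(C)C` gives 53%
- compound 2 `C=C[C@@](C)(/C=C/c1ccc(OC(=O)CCCCCCCCC)cc1)CCC=C(C)C` gives 50%
- compound 3 `C=C[C@@](C)(/C=C/c1ccc(OC(=O)CCCCCCCCCCCCCCC)cc1)CCC=C(C)C` is not yet measured

Compound 2 sits level with compound 1, the two lying within the scatter. The change to compound 3 is hexyl in place of hydrogen on a saturated chain carbon, nine bonds along the chain from a carbonyl carbon on the same chain. For the measured compounds named here, the only measured step bearing on this is a number 3 percentage points lower from compound 1 to compound 2 (within the scatter) for a shorter addition to that chain. No change beyond the scatter is therefore expected in this assay, though the longer addition leaves room for a slight downward drift. The expected step is a number 4 percentage points lower from compound 2 to compound 3 (within the scatter) on this reading. For compound 3 the estimated value is 46% within an expected range of 32% to 58%.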

Compound 3, percent growth inhibition at one concentration: 51%
The estimate for compound 3 lay 5 percentage points below the measured number; the measured number falls inside the stated range.
By their numbers in this assay, from the lowest: compounds 2, 3 and 1 (each within the scatter of the next).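

In this assay, hexyl in place of hydrogen on a saturated chain carbon, nine bonds along the chain from a carbonyl carbon, gives a number 1 percentage points higher from compound 2 to compound 3 (within the scatter). Taking the whole added length of the chain together gives a number 2 percentage points lower from compound 1 to compound 3 (within the scatter), so this position accepts a much larger addition than ethyl with the three compounds staying level. Nothing available explains this flat response.

From the compounds shown here alone, whether an amine or a carboxylic acid on the chain would move the number remains open. Going by these compounds, a longer chain than that of compound 3 also remains open.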